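The source may hold more compounds than are shown below. What is called first, only, known or untested is meant among the compounds shown, and "the series" means these compounds.

The series to hand holds three measured compounds on the shared core. In a functional assay on MCF7 cells (Homo sapiens) for antiproliferative activity, read by CCK-8 assay, with a stated time of 72 h (on this read-out lower numbers stand for stronger inhibition of growth and higher numbers for weaker inhibition of growth), compound 1 `CC[C@@H]1C(=O)N(C)c2cnc(Nc3ccc(S(=O)(=O)NCCO)cc3)nc2N1C1CCCC1` gives 344 nM; compound 2 `CCC1C(=O)N(C)c2cnc(-n3ccc4cc(C(=O)NC)ccc43)nc2N1c1ccn(C)n1` gives 35400 nM; compound 3 `CC[C@@H]1C(=O)N(C)c2cnc(-n3ccc4cc(C(=O)NCC(C)C)ccc43)nc2N1C1CCCC1` gives 953 nM. Compound 3 stands second highest of the three numbers: nearest to compound 1, whose value is lower by a margin beyond the scatter, and far from compound 2, whose value lies much higher, also beyond the scatter.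

Compound 4 `CCCNC(=O)c1ccc2c(ccn2-c2ncc3c(n2)N(C2CCCC2)[C@H](CC)C(=O)N3C)c1` has not yet been measured in this assay. It differs from compound 3 in one place: hydrogen in place of methyl on a saturated chain carbon bound to two saturated chain carbons. Cut one bond further out, the difference reads isobutyl to propyl, so the chain on the amide nitrogen is shortened while everything else in compound 3 stays.

Going by the values given here, no step between measured compounds bears on this change, so the expectation rests on the value of compound 3 alone. A change this small at the end of a saturated chain is expected to move the number from compound 3 to compound 4 by a 1.0-fold higher number from compound 3 to compound 4 (0.02 log units; within the scatter), with no direction read from the data. Compound 4 is therefore expected at 1000 nM, within a range of 400 nM to 2500 nM.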

Compound 4, concentration for 50% growth inhibition: 592 nM
Compound 4: the middle estimate sits 1.7-fold (0.23 log units) above what was measured; low and high end bracket the measured number.
By their numbers in this assay, from the lowest: compounds 1, 4 and 3 (each within the scatter of the next, the first and the last beyond it); then compound 2.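

In this assay, the series now has its first one-place step: isobutyl to propyl, with the methyl lost on a saturated chain carbon bound to two saturated chain carbons, gives a 1.6-fold lower number from compound 3 to compound 4 (0.21 log units; within the scatter). At this position, the loss of that one methyl therefore leaves the number within the scatter, so the branched and straight chains cannot be told apart on this read-out. No measurement at hand bears on this result. Still open, going by these compounds, is how far this holds along the chain: an ethyl or a longer chain such as hexyl could behave differently from the two chains seen so far. Also open, on these data alone, is what an amine or a carboxylic acid at the chain end would do to the number.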